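The source may report more compounds than this note shows. Statements on the series, on what has been measured and on what is new or still open speak of the compounds shown alone.

Two compounds that share one core have so far been examined in an assay for inhibition of Indoleamine 2,3-dioxygenase 1 (Homo sapiens), with a stated time of 1 h, tested at 10 uM; on this read-out higher numbers stand for more inhibition at the one concentration tested (going by the name of the read-out) and lower numbers for less inhibition. Compound 1, `Oc1cccc(CNc2cc(Br)cc3[nH]ncc23)c1`, bears a single hydroxy group on its benzyl ring, and in this assay compound 1 gives 45%. Compound 2, `Oc1ccc(CNc2cc(Br)cc3[nH]ncc23)c(O)c1`, bears two hydroxy groups on that ring, and in this assay compound 2 gives 40%. On paper compound 2 holds the lowest of the two readings, but its gap to compound 1 lies within the usual scatter of the measurement, so the two numbers cannot be told apart. No step beyond the scatter is therefore established between them.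

The next compound to be measured is compound 3, `Oc1ccc(CNc2cc(Br)cc3[nH]ncc23)c(F)c1`. It differs from compound 2 in one place: fluoro in place of hydroxy on an aromatic carbon.

What can be said rests only on these two readings. Compound 1 with 45% and compound 2 with 40% lie within the scatter of one another, so the hydroxy group that sets them apart has no visible effect here. On that basis the expected step in this assay is a number 2 percentage points higher from compound 2 to compound 3 (within the scatter), none beyond the scatter. Compound 3 is accordingly estimated at 42%, with a range from 25% to 60%.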

Compound 3, a percentage reported as inhibition, at one concentration (the size of the read-out at that concentration, not a potency): 69%
Beside the measured number, compound 3's estimate is 27 percentage points below it, outside the stated range (above it).
By their numbers in this assay, from the lowest: compounds 2 and 1 (each within the scatter of the next); then compound 3.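

In this assay, fluoro in place of hydroxy on the aromatic carbon ortho to a large group gives a number 29 percentage points higher from compound 2 to compound 3 (beyond the scatter), so the reading responds to what sits at this position. The earlier readings, which lay within the scatter of each other, gave no sign of such sensitivity anywhere on the benzyl ring. The step also shows that a hydroxy group at this position is not required for inhibition at the one concentration tested, but nothing available explains the gain.

From the compounds shown here alone, what remains open is whether the gain comes from the fluorine itself or simply from the loss of the hydroxy group, a question that a plain hydrogen, a chlorine or a methoxy group at the same carbon would help to settle. Going by these compounds, it is also open whether the remaining hydroxy group, meta to the fluoro, contributes to the reading of compound 3, which a methoxy group or an amine in its place could test.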